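The source may hold more compounds than are shown below. What is called first, only, known or untested is meant among the compounds shown, and "the series" means these compounds.

Compound 1 `CSc1nnc(COc2cc(C)c3c(C)cc(=O)oc3c2)o1`: > 100000 nM
Compound 2 `CCCCSc1nnc(COc2cc(C)c3c(C)cc(=O)oc3c2)o1`: > 100000 nM
Compound 3 `CCCS(=O)(=O)c1nnc(COc2cc(C)c3c(C)cc(=O)oc3c2)o1`: 7070 nM

In a functional assay on MDA-MB-231 cells (Homo sapiens) for antiproliferative activity, read by MTT assay, with a stated time of 24 h (on this read-out higher numbers stand for weaker inhibition and lower numbers for stronger inhibition), compound 1 gives > 100000 nM, which is a limit of the assay and not a number. Compound 2 gives > 100000 nM, again a limit. Within the data shown here, compound 3 gives 7070 nM, the only number among the three. The change from compound 1 to compound 2 is propyl in place of hydrogen on a saturated chain carbon bound to a sulfur; its step that the two limits leave unreadable from compound 1 to compound 2 cannot be sized because both values sit at the limit of > 100000 nM in this assay, at which 2 of the 3 values shown sit. The cores of compound 1 and compound 3 differ by propylsulfonyl in place of methylsulfanyl on an aromatic carbon, and that change gives an at least 14-fold lower number from compound 1 to compound 3 (1.15 log units; beyond the scatter); from compound 2 the step is an at least 14-fold lower number from compound 2 to compound 3 (1.15 log units; beyond the scatter).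

Compound 4 `CCCCCCS(=O)(=O)c1nnc(COc2cc(C)c3c(C)cc(=O)oc3c2)o1` differs from compound 3 by propyl in place of hydrogen on a saturated chain carbon, three bonds along the chain from a sulfonyl sulfur. This is the same kind of change as from compound 1 to compound 2, yet the place is not identical: there the added propyl sat on a saturated chain carbon bound to a sulfur, here on a saturated chain carbon three bonds along the chain from a sulfonyl sulfur. Since the earlier step is unreadable, the expectation rests on compound 3 alone, whose value 7070 nM is taken as the anchor. The step from compound 3 to compound 4 is expected to be small, a 1.0-fold lower number from compound 3 to compound 4 (0.00 log units; within the scatter). Compound 4 is therefore estimated at 7000 nM, with a likely range from 2000 nM to 30000 nM.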

Compound 4, half-maximal inhibitory concentration: > 100000 nM
Compound 4 was reported as a limit; the forecaster's own chance of this, stated with the estimate: 12%; middle value at least 14-fold (1.15 log units) away from the limit.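

In this assay, propyl in place of hydrogen on a saturated chain carbon, three bonds along the chain from a sulfonyl sulfur, gives an at least 14-fold higher number from compound 3 to compound 4 (1.15 log units; beyond the scatter). Compound 4 gives > 100000 nM, which is a limit of the assay and not a number. This large loss is therefore seen on the sulfonyl compounds only, and it does not show how the change carries to another core, since the like step from compound 1 to compound 2 and the steps from compound 1 and from compound 2 to compound 4 cannot be read: the limit of > 100000 nM in this assay, at which 3 of the 4 values shown sit.

The compounds shown leave open how a butylsulfonyl or pentylsulfonyl chain would behave. They also leave open whether an amine or a carboxylic acid at the end of the hexyl chain would change the result.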